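Benzimidazole to fused pyridine: stability note

The compounds below may be only part of what the source reports. "The series", "measured", "known", "first", "only" and "open" are said of these compounds alone.

Two members of this series have been run in an ADME assay on microsomes from liver (Homo sapiens) for metabolic stability, read by LC-MS, with a stated time of 10 min, tested at 0.5 uM; a higher number here means that more of the compound is left, a lower number that less of the compound is left. Compound 1 `c1cnc2c(c1)CCC[C@@H]2N(CCCN1CCNCC1)Cc1nc2ccccc2[nH]1` gives 63% in this assay. Compound 2 `CC(C)N1CCN(CCCN(C[C@H]2Cc3ccccc3CN2)[C@H]2CCCc3cccnc32)CC1`, which carries different groups on the amine nitrogen and on the terminal piperazine, gives 46% in this assay, so compound 1 stands highest of the two numbers, and the gap to compound 2 lies beyond the usual scatter. For the measured compounds named here, no pair of measured compounds differs in a single place, so no isolated step is available.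

Compound 3 `c1cnc2c(c1)CN[C@@H](CN(CCCN1CCNCC1)[C@H]1CCCc3cccnc31)C2` has not yet been run. Relative to compound 1 it differs in one place (a group of 10 heavy atoms (8 carbon, 2 nitrogen; one six-membered non-aromatic ring with 1 hetero atom, one six-membered aromatic ring with 1 hetero atom) in place of a group of 9 heavy atoms (7 carbon, 2 nitrogen; one five-membered aromatic ring with 2 hetero atoms, one six-membered aromatic ring of carbon only), on a saturated chain carbon bound to an amine nitrogen). The entering group shares the saturated-ring-plus-pyridine character seen elsewhere in the shared core, and the other compound that carries a saturated nitrogen ring on that side of the amine, compound 2, sits lower at 46%. On that thin basis a downward step of moderate size is expected, roughly at the edge of the scatter, written as a number 13 percentage points lower from compound 1 to compound 3 (beyond the scatter). For compound 3 the expected value in this assay is 50%, with a range from 30% to 70%.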

Compound 3, percent of the compound remaining: 79%
For compound 3 the middle estimate is 29 percentage points below the measured one; measured number above the stated range.
By their numbers in this assay, from the lowest: compound 2; then compound 1; then compound 3.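

In this assay, for the compounds shown here, putting the entering group in place of 1H-benzimidazol-2-yl, on a saturated chain carbon bound to an amine nitrogen, gives a number 16 percentage points higher from compound 1 to compound 3 (beyond the scatter), the first reading of a single change. It shows that the 1H-benzimidazol-2-yl group is not needed at this place to keep the compound at this level, and that a group with one six-membered non-aromatic ring with 1 hetero atom and one six-membered aromatic ring with 1 hetero atom is accepted there without any loss in this read-out. The change alters the ring types, the hydrogen-bond acceptor count and the defined stereocentre together, and nothing measured here bears on which of these accounts for the rise.

Going by these compounds alone, compound 2 differs from the other two compounds in more than one place, so no step involving it can be read. Still open, as far as these compounds go, is how a phenyl group or an open-chain amine would behave at this place, and whether the opposite configuration at the defined stereocentre of the entering group would hold the number seen for compound 3.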